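This account rests on a few compounds, and the source may have more. Where it says the series, first, only, none or still open, it means among the compounds named here.

Measured so far:
compound 1 `Oc1ccc(-c2cc(-c3ccsc3)cc(-c3cccc(O)c3)n2)cc1` — 2230 nM
compound 2 `Oc1ccc(-c2cc(-c3ccsc3)cc(-c3ccc(O)cc3)n2)cc1` — 2060 nM

Both values come from a functional assay on DU-145 cells (Homo sapiens) for cytotoxicity, read by CCK-8 assay; on this read-out higher numbers stand for weaker inhibition and lower numbers for stronger inhibition. Compound 1 gives the highest of the two numbers, but its nearest neighbour, compound 2, sits within the scatter of it: a 1.1-fold lower number from compound 1 to compound 2 (0.03 log units; within the scatter). The two compounds differ only in the placement of one hydroxyl on a phenyl group, and on the numbers shown this exchange does not register beyond the noise.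

Compound 3 `Oc1ccc(-c2cc(-c3ccoc3)cc(-c3cccc(O)c3)n2)cc1` has not yet been measured in this assay. It differs from compound 1 in one place: furan-3-yl in place of thiophen-3-yl on an aromatic carbon. Among the measured compounds shown here, no measured step concerns this exchange; the only step on hand, from compound 1 to compound 2, touches a different part of the shared core and is itself within the scatter. There is thus no basis in the series for expecting a shift in either direction beyond the scatter, and compound 3 is expected to stay close to compound 1, with the step of a 1.1-fold higher number from compound 1 to compound 3 (0.05 log units; within the scatter) estimated as essentially flat. The expected value for compound 3 in this assay is 2500 nM, with a range from 1000 nM to 6500 nM.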

Compound 3, half-maximal inhibitory concentration: 2700 nM
Compound 3: middle estimate off by 1.1-fold (0.03 log units), on the low side; low and high end bracket the measured number.
By their numbers in this assay, from the lowest: compounds 2, 1 and 3 (each within the scatter of the next).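

In this assay the position opposite the ring nitrogen now carries its first readable exchange: furan-3-yl in place of thiophen-3-yl gives a 1.2-fold higher number from compound 1 to compound 3 (0.08 log units; within the scatter) and so does not register beyond the noise. The earlier step concerned only the placement of a hydroxyl on a phenyl group, whereas this one shows that the five-membered aromatic ring at this position can change its hetero atom from sulfur to oxygen without a detectable shift in the cellular number. The two groups match in heavy-atom count, ring size and hydrogen-bond counts, so the comparison isolates that single atom and says nothing about larger changes at this position. No measured information on these compounds accounts for the flat result.

Open questions remain about whether this position stays equally flat with a group of another kind, such as a primary amine, a carboxylic acid or a longer alkyl chain, in place of the five-membered ring. Also open, as far as these compounds go, is whether a methoxy group in place of either hydroxyl would move the number beyond the scatter.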